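This account rests on a few compounds, and the source may have more. Where it says the series, first, only, none or still open, it means among the compounds named here.

Series so far in an ADME assay on cells (Epithelial cell, Homo sapiens) for antiproliferative activity, read by MTT assay, with a stated time of 48 h; on this read-out lower numbers stand for stronger inhibition and higher numbers for weaker inhibition:
- compound 1 `COC(=O)/C(=C/c1ccccc1)CN1C(=O)[C@@H](OC)[C@H]1c1ccc(F)cc1` gives 27900 nM
- compound 2 `CCOC(=O)/C(=C/c1ccccc1)CN1C(=O)[C@@H](OC)[C@H]1c1cccc([N+](=O)[O-])c1` gives "not toxic" (no number reported)
- compound 3 `COC(=O)/C(=C/c1ccccc1)CN1C(=O)[C@@H](OC)[C@H]1c1ccc(OC)cc1` gives "not toxic" (no number reported)

Compound 2 has no single number on this scale, and compound 3 is the one further entry without a number. For the measured compounds named here, compound 2 therefore cannot be ranked numerically, and compound 1 holds the only numeric value.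

Next is compound 4 `CCOC(=O)/C(=C/c1ccccc1)CN1C(=O)[C@@H](OC)[C@H]1c1ccc(F)cc1`, not yet measured in this assay. The structural change is 4-fluorophenyl in place of 3-nitrophenyl on a saturated ring carbon and it falls on a saturated ring carbon next to the ring nitrogen, where 4-fluorophenyl stands in place of 3-nitrophenyl.

Going by the values given here, no measured step is available to size this change, and compound 2 offers no number to step from. Among the compounds with values here, the expected direction is toward stronger inhibition, with a measurable value rather than another entry without a number, but no size of step can be stated. Within the data shown here, the only anchor is compound 1, which carries the same 4-fluorophenyl group and gives 27900 nM in this assay. One value is thin support, so the range is kept wide.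

Compound 4 is expected at 30000 nM, with an estimated range from 12000 nM to 80000 nM in this read-out.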

Compound 4, half-maximal inhibitory concentration: "not toxic" (no number reported)
No number was reported for compound 4; the estimate stays without a comparison.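

In this assay compound 2 and compound 4 are both reported as "not toxic" without a number, so no step can be read between them. The compounds shown leave open how far either lies from compound 1, which gives 27900 nM on this scale. No measurement shown bears on this result.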